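The source may report more compounds than this note shows. Statements on the series, on what has been measured and on what is new or still open speak of the compounds shown alone.

Of the compounds shown here, three sharing one core have been measured in a physicochemical assay for lipophilicity, measured as octanol-water partition, at pH 7.4 (on this read-out higher numbers stand for higher lipophilicity and lower numbers for lower lipophilicity), and they differ only in the ring group on a saturated ring carbon. Compound 1 (`O=C([C@H](O)CS(=O)(=O)c1ccc2cc(Cl)ccc2c1)N1CCC(N2CCNC2=O)CC1`) gives 1.73, compound 2 (`O=C([C@H](O)CS(=O)(=O)c1ccc2cc(Cl)ccc2c1)N1CCC(n2cc[nH]c2=O)CC1`) gives 1.79, and compound 3 (`O=C([C@H](O)CS(=O)(=O)c1ccc2cc(Cl)ccc2c1)N1CCC(N2CCOC2=O)CC1`) gives 1.75. Compound 3 therefore stands within the scatter of both other compounds, and the three values cannot be ranked.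

The unmeasured compound 4 (`O=C([C@H](O)CS(=O)(=O)c1ccc2cc(Cl)ccc2c1)N1CCC(N2CCCOC2=O)CC1`) departs from compound 3 in a single place: a group of 7 heavy atoms (4 carbon, 1 nitrogen, 2 oxygen; one six-membered non-aromatic ring with 2 hetero atoms) in place of a group of 6 heavy atoms (3 carbon, 1 nitrogen, 2 oxygen; one five-membered non-aromatic ring with 2 hetero atoms), on a saturated ring carbon. Among the measured compounds shown here, the six-membered non-aromatic ring of compound 4 has no measured counterpart in this set. For the measured compounds named here, the only evidence comes from exchanges among the five-membered groups, which gave a number 0.02 log units higher from compound 1 to compound 3 (within the scatter), a number 0.06 log units higher from compound 1 to compound 2 (within the scatter) and a number 0.04 log units lower from compound 2 to compound 3 (within the scatter). None of these steps changes the ring size, so they bear on the new change only indirectly. They do show that three different groups at this place left the read-out of this assay within the scatter. On that limited evidence, a small upward move is expected, with nothing beyond the scatter, and the estimated step is a number 0.10 log units higher from compound 3 to compound 4 (within the scatter). Compound 4 is expected at 1.85, with an estimated range of 1.55 to 2.15.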

Compound 4, distribution coefficient: 1.67
Compound 4: middle estimate off by 0.18 log units, on the high side; the measured number falls inside the stated range.
By their numbers in this assay, from the lowest: compounds 4, 1, 3 and 2 (each within the scatter of the next).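

In this assay, among the compounds shown here, the step to a six-membered non-aromatic ring, a change that no earlier compound carried, gave a number 0.08 log units lower from compound 3 to compound 4 (within the scatter) and so stayed inside the scatter, as the exchanges among the five-membered groups had done. The comparisons with the other two groups read the same way, with a number 0.06 log units lower from compound 1 to compound 4 (within the scatter) and a number 0.12 log units lower from compound 2 to compound 4 (within the scatter) both within the scatter, so the four groups on this saturated ring carbon cannot be told apart by this read-out, whether the ring is five-membered or six-membered, aromatic or non-aromatic. No measurement is available that would account for these values staying together at this position.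

The compounds shown leave open whether the same holds for groups of another kind at this place, such as an amine, a carboxylic acid or an open-chain urea in place of the ring. They also leave open whether a six-membered cyclic urea, the ring-enlarged counterpart of the 2-oxoimidazolidin-1-yl group of compound 1, or a seven-membered ring would stay within the scatter as well.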